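The source may hold more compounds than are shown below. What is called first, only, known or untested is meant among the compounds shown, and "the series" means these compounds.

Measured so far:
compound 1 `CC1=C(C(=O)NC2CCCCC2)C(c2ccccc2)NC(=O)N1` in an ADME assay on Vero cells (Chlorocebus sabaeus) for cytotoxicity, read by XTT assay, with a stated time of 72 h; on this read-out higher numbers stand for lower toxicity in this test and lower numbers for higher toxicity in this test: > 100000 nM
compound 2 `CC1=C(C(=O)Nc2ccccc2Cl)C(c2ccccc2Cl)NC(=O)N1` in this assay: "non-toxic" (no number reported)

Compound 1 gives only a limit of the assay in this assay, namely > 100000 nM. Compound 2 gives no number at all in this assay, only the word "non-toxic" (no number reported). So compound 2 cannot be placed on a scale of numbers; the one other value shown sits at the limit of > 100000 nM in this assay, at which 1 of the 2 values shown sits, and compound 2 is described in the same non-toxic way, without a figure.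

Compound 3 `CC1=C(C(=O)Nc2ccccc2Cl)C(c2cccc(Br)c2)NC(=O)N1` has not been measured. It differs from compound 2 in one place: 3-bromophenyl in place of 2-chlorophenyl on a saturated ring carbon. Among the measured compounds shown here, no measured pair shows what such a change does in this assay, so the expected step is none beyond the scatter, with no direction. Compound 3 is expected to give about 100000 nM, within 30000 nM to 300000 nM, most likely reported again only as a limit of the assay.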

Compound 3, half-maximal cytotoxic concentration: > 100000 nM
Compound 3: only a limit was reported; the forecaster's own chance of this, stated with the estimate: 80%; the middle value lies on the limit itself.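

No step can be read from compound 2 to compound 3 in this assay. Compound 3 gives only a limit, not a number: the limit of > 100000 nM in this assay, at which 2 of the 3 values shown sit.

The compounds shown leave open at what concentration, if any, either compound would harm these cells, and whether 3-bromophenyl in place of 2-chlorophenyl changes that.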